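The compounds below may be only part of what the source reports. "The series", "measured", "known", "first", "only" and "open" are said of these compounds alone.

Measured so far:
compound 1, `CCOc1ccc(Br)cc1C(C)NC(=O)N(C)S(=O)(=O)c1ccc(Cl)cc1`, 55700 nM
compound 2, `CCOc1ccc(Br)cc1C(C)NC(=O)NS(=O)(=O)c1ccccc1`, > 300000 nM, a limit of the assay
compound 3, `CC(NC(=O)N(C)S(=O)(=O)c1ccc(Cl)cc1)c1cc(Br)ccc1OCc1ccccc1`, 146000 nM

In a functional assay on thoracic aorta (Rattus norvegicus, strain Wistar), with a stated time of 15 min (on this read-out higher numbers stand for an effect only at larger amounts of compound and lower numbers for an effect already at smaller amounts), compound 1 gives 55700 nM and compound 3 gives 146000 nM. For compound 2 the assay reports no number but only a limit, > 300000 nM. Compound 4, `CC(NC(=O)NS(=O)(=O)c1ccccc1)c1cc(Br)ccc1OCc1ccccc1`, has not yet been measured. The difference between the core of compound 1 and the core of compound 2 is not broken down here. From compound 1 to compound 3 the change is phenyl in place of methyl on a saturated chain carbon bound to an oxygen on an aromatic ring, and it produced a 2.6-fold higher number from compound 1 to compound 3 (0.42 log units; beyond the scatter). From compound 2 to compound 4 the same change is made: phenyl in place of methyl on a saturated chain carbon bound to an oxygen on an aromatic ring. Because compound 2 already sits at the limit of > 300000 nM in this assay, at which 1 of the 3 values shown sits, any weakening of compound 4 would again lie beyond what this assay can report, so a second limit is the most likely outcome. For compound 4 a step that the limit leaves unreadable from compound 2 to compound 4 is expected, resting on a 2.6-fold higher number from compound 1 to compound 3 (0.42 log units; beyond the scatter) carried over from compound 2. Compound 4 is estimated at 700000 nM, with a likely range from 300000 nM to 2500000 nM.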

Compound 4, half-maximal effective concentration: 130000 nM
The estimate for compound 4 lay 5.4-fold (0.73 log units) above the measured number, and the stated range ends above it.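

In this assay, putting phenyl in place of methyl on a saturated chain carbon bound to an oxygen on an aromatic ring, which turns ethoxy into benzyloxy, gave an at least 2.3-fold lower number from compound 2 to compound 4 (0.36 log units; beyond the scatter), so on these two cores the change does not carry over in the same direction: the same change on two cores in this assay, a 2.6-fold higher number (0.42 log units; beyond the scatter) from compound 1 to compound 3 and an at least 2.3-fold lower number (0.36 log units; beyond the scatter) from compound 2 to compound 4, at least 6.0-fold (0.78 log units) apart, beyond the scatter of two such steps. Compound 2 has only a limit of the assay, > 300000 nM, so the true size of this step stays unread. The result shows that a step seen on one core cannot simply be transferred to the other, but two pairs of compounds do not explain the difference or set a rule for the wider series.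

On these data alone, the core of compound 1 and the core of compound 2 differ in more than one place, and which of those differences decides the outcome stays open. Also open, as far as these compounds go, is how a longer chain such as propyl, or an amine or a carboxylic acid in place of the phenyl, would behave on each core.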